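Swapping the acetyl aryl for a dimethyl aryl

The compounds below may be only part of what the source reports. "The series", "measured", "known", "first", "only" and "open" are said of these compounds alone.

The series is followed in a functional assay (aorta) with Rattus norvegicus as the target; on this read-out lower numbers stand for stronger inhibition and higher numbers for weaker inhibition. Compound 1 `CC1(C)Oc2ccc(C#N)cc2[C@@H](/N=C(\NC#N)Nc2ccccc2)[C@@H]1O` is entered twice, giving 1400 nM; 1300 nM (2 entries), and these repeated entries the several entries of compound 1 in this assay, 1400 nM; 1300 nM (2 entries) show how closely one measurement can be reproduced here. Compound 2 `CC1(C)Oc2ccc(C#N)cc2[C@@H](N2CCN(c3ccccc3)C2=O)[C@@H]1O` gives 23700 nM. Compound 3 `CC(=O)c1cccc(N/C(=N/[C@@H]2c3cc(C#N)ccc3OC(C)(C)[C@H]2O)NC#N)c1` gives 8400 nM, which places it at the lowest of the two single numbers; its nearest neighbour is compound 2, whose number stands beyond the scatter above it, while compound 1 contributes only its pair of entries.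

Compound 4 `Cc1ccc(N/C(=N/[C@@H]2c3cc(C#N)ccc3OC(C)(C)[C@H]2O)NC#N)cc1C` has not yet been measured in this assay. It differs from compound 3 in one place: 3,4-dimethylphenyl in place of 3-acetylphenyl on an amine nitrogen. Among the compounds with values here, no measured pair in this set shares that kind of change, so the step can only be judged against the spread of the numbers already seen. Compound 3 stands above the entries of compound 1, and a move in this assay toward lower numbers is expected for compound 4, of a size a 2.1-fold lower number from compound 3 to compound 4 (0.32 log units; beyond the scatter) that goes beyond the scatter but stays short of the level of compound 1. On that basis compound 4 is estimated at 4000 nM, within a range from 1000 nM to 16000 nM.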

Compound 4, half-maximal inhibitory concentration: 5100 nM
Estimate against measurement, compound 4: 1.3-fold (0.11 log units) below, within the range that was stated.
By their numbers in this assay, from the lowest: compounds 4 and 3 (each within the scatter of the next); then compound 2.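

In this assay, replacing the 3-acetylphenyl on this amine nitrogen with 3,4-dimethylphenyl gives a 1.6-fold lower number from compound 3 to compound 4 (0.22 log units; within the scatter). The two aryl groups therefore cannot be told apart in this assay, although the group that leaves carries a hydrogen-bond acceptor and the group that enters carries none. Compound 4 gives 5100 nM, still a higher number than compound 1, which has a plain phenyl at this place and whose repeated entries agree closely: the several entries of compound 1 in this assay, 1400 nM; 1300 nM (2 entries).

The compounds shown leave open whether a single methyl group, a chlorine or a methoxy group on this phenyl ring would read differently. They also leave open whether either methyl group of compound 4 matters on its own.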